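The source may report more compounds than this note shows. Statements on the series, on what has been measured and on what is new or still open speak of the compounds shown alone.

Compound 1 `COc1cc(/C=C/C(=O)OCCCO[N+](=O)[O-])ccc1OCCCO[N+](=O)[O-]` was tested in a functional assay on A549 cells (Homo sapiens) for cytotoxicity, read by resazurin assay, with a stated time of 72 h (on this read-out higher numbers stand for weaker inhibition and lower numbers for stronger inhibition), and gave 15800 nM. Compound 3 `COc1cc(/C=C/C(=O)OCCCCCCO[N+](=O)[O-])ccc1OCCCCCCO[N+](=O)[O-]` differs from compound 1 in more than one place; the difference between the two cores is not broken down here. In this assay compound 3 reached only > 50000 nM, which is a limit of the measurement rather than a number. Compound 2 `O=C(/C=C/c1ccc(OCCCCCCO[N+](=O)[O-])c(O)c1)OCCCCCCO[N+](=O)[O-]` likewise sits at the limit > 50000 nM in this assay. The change hydrogen in place of methyl on an oxygen on an aromatic ring gave a step that the two limits leave unreadable from compound 3 to compound 2, unreadable because both values sit at the limit of > 50000 nM in this assay, at which 2 of the 3 values shown sit. Compound 4 `O=C(/C=C/c1ccc(OCCCO[N+](=O)[O-])c(O)c1)OCCCO[N+](=O)[O-]` carries the same change from compound 1: hydrogen in place of methyl on an oxygen on an aromatic ring. The expected step of a 1.3-fold higher number from compound 1 to compound 4 (0.10 log units; within the scatter) rests on compound 1 giving 15800 nM and on the same change giving only a step that the two limits leave unreadable from compound 3 to compound 2, so little shift is assumed. Compound 4 is therefore estimated at 20000 nM, between 7000 nM and 55000 nM.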

Compound 4, half-maximal inhibitory concentration: 690 nM
Beside the measured number, compound 4's estimate is 29-fold (1.46 log units) above it; the whole stated range lies above it.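

In this assay, replacing methoxy with hydroxy gave a 23-fold lower number from compound 1 to compound 4 (1.36 log units; beyond the scatter), so on this core the change moves the number well beyond the usual scatter, towards stronger inhibition. The same change from compound 3 to compound 2 cannot be read, because each of these two compounds gives a limit of the assay and not a number: the limit of > 50000 nM in this assay, at which 2 of the 4 values shown sit. The large step is therefore shown on one core only, and the compounds do not show whether it carries over to the core of compound 3, where the chains differ.

On these data alone, whether an amine in place of the hydroxy would keep the lower number stays open. So does the effect of the hydroxy on a core with a longer chain than that of compound 2.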